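Removing the Methoxy Group from Compound 3

The source may report more compounds than this note shows. Statements on the series, on what has been measured and on what is new or still open speak of the compounds shown alone.

Three measured compounds share one core and differ only in the ring attached to the sulfonamide nitrogen: compound 1 `O=C1NCCN1c1ccc(S(=O)(=O)Nc2ccc(C3CCCCC3)cc2)cc1`, compound 2 `O=C1NCCN1c1ccc(S(=O)(=O)Nc2ccc(I)cc2)cc1` and compound 3 `COc1cccc(NS(=O)(=O)c2ccc(N3CCNC3=O)cc2)c1`. In a functional assay on M21 cells (Homo sapiens) for antiproliferative activity, read by sulforhodamine B assay, with a stated time of 48 h (a lower number here means a stronger inhibitor, a higher number a weaker inhibitor), compound 1 reaches only a limit, > 1000 nM, which marks the edge of the measurement (the limit of > 1000 nM in this assay, at which 1 of the 3 values shown sits). In this assay compound 2 gives 260 nM, while compound 3 gives 65 nM. The step of an at least 3.8-fold lower number from compound 1 to compound 2 (0.58 log units; beyond the scatter) and the step of a 4.0-fold lower number from compound 2 to compound 3 (0.60 log units; beyond the scatter) together place compound 3 at the lowest number among the values that are numbers.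

Compound 4 `O=C1NCCN1c1ccc(S(=O)(=O)Nc2ccccc2)cc1` differs from compound 3 by hydrogen in place of methoxy on an aromatic carbon. Going by the values given here, neither measured step removes a group without putting another in its place, so no step bears directly on this change; both measured steps were modest in size. The expected change is therefore small, a 1.7-fold higher number from compound 3 to compound 4 (0.23 log units; within the scatter), at or just beyond the scatter toward a higher number. Compound 4 is estimated at 110 nM, within a range from 45 nM to 270 nM.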

Compound 4, half-maximal inhibitory concentration: 200 nM
For compound 4 the middle estimate is 1.8-fold (0.26 log units) below the measured one; measured number inside the range.
By their numbers in this assay, from the lowest: compound 3; then compounds 4 and 2 (each within the scatter of the next). At a limit, above all of these: compound 1.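

In this assay, taking the methoxy group off gives a 3.1-fold higher number from compound 3 to compound 4 (0.49 log units; beyond the scatter), so the lower number of compound 3 is tied to this group, which a plain phenyl ring does not replace. Hydrogen in place of iodo gives a 1.3-fold lower number from compound 2 to compound 4 (0.11 log units; within the scatter), so phenyl and 4-iodophenyl cannot be told apart in this assay. Hydrogen in place of cyclohexyl gives an at least 5.0-fold lower number from compound 1 to compound 4 (0.69 log units; beyond the scatter), but this step starts from a limit rather than a true number: the limit of > 1000 nM in this assay, at which 1 of the 4 values shown sits.

The compounds shown leave open whether methoxy is special at this place, or whether a hydroxyl group, an ethoxy group or an amine on the same carbon would serve equally well. They also leave open how methoxy would behave on the other carbons of the ring.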